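This account rests on a few compounds, and the source may have more. Where it says the series, first, only, none or still open, it means among the compounds named here.

Working notes on the aryl ester series. The shared core is carried unchanged through compounds 1 to 4; the variation sits in the aryl group on the ester carbonyl. Compound 1 `COC(=O)/C(=C\c1ccc(OC(=O)c2ccc(OC)cc2)cc1)Sc1ccnc2cc(Cl)ccc12` gives 9090 nM in a functional assay on HL-60 cells (Homo sapiens) for cytotoxicity, read by MTT assay, with a stated time of 24 h; a lower number here means a stronger inhibitor, a higher number a weaker inhibitor. Compound 2 `COC(=O)/C(=C\c1ccc(OC(=O)c2cccc(OC)c2)cc1)Sc1ccnc2cc(Cl)ccc12` gives 25500 nM in this assay. Compound 3 `COC(=O)/C(=C\c1ccc(OC(=O)c2ccccc2OC)cc1)Sc1ccnc2cc(Cl)ccc12` gives 44500 nM in this assay, the highest number of the three: a 4.9-fold higher number from compound 1 to compound 3 (0.69 log units; beyond the scatter) lies beyond the scatter, whereas a 1.7-fold higher number from compound 2 to compound 3 (0.24 log units; within the scatter) stays within it, and a 2.8-fold higher number from compound 1 to compound 2 (0.45 log units; beyond the scatter) is modest. Compound 4 `COC(=O)/C(=C\c1ccc(OC(=O)c2ccc(OC)c(OC)c2)cc1)Sc1ccnc2cc(Cl)ccc12` is not yet measured. The change is 3,4-dimethoxyphenyl in place of 2-methoxyphenyl on a carbonyl carbon. The 4-methoxyphenyl pattern of compound 1 returns within the entering group, with a 3-methoxy added. The step that bears most directly is a 4.9-fold higher number from compound 1 to compound 3 (0.69 log units; beyond the scatter), read in reverse; a 2.8-fold higher number from compound 1 to compound 2 (0.45 log units; beyond the scatter) marks what the added 3-methoxy alone did. A lower number than compound 3 is expected, landing between the numbers of compound 1 and compound 2. Compound 4 is expected to give about 13000 nM in this assay, within 5000 nM to 35000 nM. The expected step is a 3.4-fold lower number from compound 3 to compound 4 (0.53 log units; beyond the scatter).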

Compound 4, half-maximal inhibitory concentration: 5290 nM
Compound 4: middle estimate off by 2.5-fold (0.39 log units), on the high side; measured number inside the range.
By their numbers in this assay, from the lowest: compounds 4 and 1 (each within the scatter of the next); then compounds 2 and 3 (each within the scatter of the next).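

In this assay, the 3,4-dimethoxyphenyl group on the carbonyl carbon groups with the 4-methoxyphenyl group of compound 1, not with the other two: methoxy in place of hydrogen on an aromatic carbon stays within the scatter in one direction (a 1.7-fold lower number from compound 1 to compound 4 (0.24 log units; within the scatter)) but gives a step beyond it in the other (a 4.8-fold lower number from compound 2 to compound 4 (0.68 log units; beyond the scatter)). Going by these compounds alone, the 3-methoxy that went with a higher number in compound 2 therefore carries no such cost in compound 4, where the 4-methoxy is also present, and the step from the 2-methoxyphenyl group is the largest so far (an 8.4-fold lower number from compound 3 to compound 4 (0.92 log units; beyond the scatter)). Nothing at hand explains this dependence on the second methoxy.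

Open, going by these compounds, is whether the 4-methoxy can be replaced, for example by a hydroxyl, an amine or a chlorine on the same ring. Also open, on these data alone, is whether a 3,4,5-trimethoxyphenyl group would keep the number of compound 4.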